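The source may report more compounds than this note shows. Statements on the series, on what has been measured and on what is new or still open speak of the compounds shown alone.

Within the data shown here, compound 2, `CCOC(=O)c1c(-c2ccc(OC)cc2)c(C#N)c(=O)n(/N=C(\C)c2ccc(NS(=O)(=O)c3ccc(Cl)cc3)cc2)c1N`, gives 61700 nM in a functional assay on HepG2 cells (Homo sapiens) for cytotoxicity, read by sulforhodamine B assay, with a stated time of 48 h (on this read-out lower numbers stand for stronger inhibition and higher numbers for weaker inhibition), the higher of the two numbers measured so far; compound 1, `CCOC(=O)c1c(-c2ccco2)c(C#N)c(=O)n(/N=C(\C)c2ccc(NS(=O)(=O)c3ccc(Cl)cc3)cc2)c1N`, gives 10300 nM, and the step of a 6.0-fold higher number from compound 1 to compound 2 (0.78 log units; beyond the scatter) separates them. Compound 3, `CCOC(=O)c1c(-c2cccc([N+](=O)[O-])c2)c(C#N)c(=O)n(/N=C(\C)c2ccc(NS(=O)(=O)c3ccc(Cl)cc3)cc2)c1N`, differs from compound 2 by 3-nitrophenyl in place of 4-methoxyphenyl on an aromatic carbon. Among the measured compounds shown here, only the step of a 6.0-fold higher number from compound 1 to compound 2 (0.78 log units; beyond the scatter) bears on swapping this aromatic substituent, and it was modest. Because a 6.0-fold higher number from compound 1 to compound 2 (0.78 log units; beyond the scatter) shows that this position matters, compound 3 is expected to move by a 2.1-fold lower number from compound 2 to compound 3 (0.31 log units; beyond the scatter) toward the middle of the measured range. Compound 3 is therefore estimated at 30000 nM, in the range 8000 nM to 100000 nM.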

Compound 3, half-maximal inhibitory concentration: 29700 nM
Compound 3: middle estimate off by 1.0-fold (0.00 log units), on the high side; the range from low to high includes it.
By their numbers in this assay, from the lowest: compound 1; then compound 3; then compound 2.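

In this assay, the position gives a graded series rather than a single jump, with a 2.1-fold lower number from compound 2 to compound 3 (0.32 log units; beyond the scatter) and a 2.9-fold higher number from compound 1 to compound 3 (0.46 log units; beyond the scatter) placing 3-nitrophenyl between 4-methoxyphenyl and furan-2-yl. Two groups with a six-membered carbon ring therefore differ from each other, and both give higher numbers than furan-2-yl. No supporting measurement explains this order.

The swap changes both the substituent and where it sits on the phenyl ring, so those two contributions cannot be separated. From the compounds shown here alone, whether 3-methoxyphenyl, 4-nitrophenyl or a phenyl ring bearing an amine would fit this order remains open.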